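Replacing a chlorobenzyl group with phenyl on the core

A few compounds are considered here, and "the series" means these few. Any claim that something is new, unique, unknown or untested is made for them only; others in the source may bear on it.

Measured compounds:
- Compound 1 `CCOC(=O)c1ccc(-c2nn(Cc3cccc(Cl)c3)c3ccccc23)cc1`: > 10000 nM
- Compound 2 `NC(=O)c1ccc(-c2nn(Cc3ccccc3)c3ccccc23)cc1`: > 10000 nM

In a functional assay on cells (Platelet, Homo sapiens) for inhibition (on this read-out lower numbers stand for stronger inhibition and higher numbers for weaker inhibition), compound 1 gives only a limit of the assay, > 10000 nM, and no number. Compound 2 likewise reaches only a limit in this assay, > 10000 nM. Both shown values sit at the limit of > 10000 nM in this assay, at which 2 of the 2 values shown sit, so compound 1 stands at that limit alongside compound 2, with nothing to separate the two. The unmeasured compound 3 `CCOC(=O)c1ccc(-c2nn(-c3ccccc3)c3ccccc23)cc1` differs from compound 1 by phenyl in place of 3-chlorobenzyl on an aromatic nitrogen. With both known values at the limit, no step within the shown data can be measured, and no step beyond the scatter is expected. Compound 3 is expected to give 15000 nM, in the range 5000 nM to 50000 nM. The step that the limit leaves unreadable from compound 1 to compound 3 is an estimate that expects compound 3 to remain at the limit.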

Compound 3, half-maximal inhibitory concentration: > 10000 nM
Compound 3: only a limit was reported; the forecaster's own chance of this, stated with the estimate: 85%; the middle value is on the limit's open side.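

Compound 1 and compound 3 both reach only a limit in this assay, so no step can be read between them: the limit of > 10000 nM in this assay, at which 3 of the 3 values shown sit. The compounds shown leave open which change to the shared core, if any, would give a measurable value.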